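Expected effect of ethoxycarbonyl on compound 2

A few compounds are considered here, and "the series" means these few. Any claim that something is new, unique, unknown or untested is made for them only; others in the source may bear on it.

In an ADME assay on Vero 76 cells (Chlorocebus sabaeus) for cytotoxicity, read by crystal violet staining, with a stated time of 96 h (on this read-out lower numbers stand for higher toxicity in this test and higher numbers for lower toxicity in this test), compound 1 (`FC(F)(F)c1cccc(NC(=S)Nc2ccc(Cl)cc2)c1`) gives 11000 nM and compound 2 (`FC(F)(F)c1cccc(NC(=S)Nc2ccccc2)c1`) gives 39000 nM as the higher of the two numbers, which stands for the lower toxicity of this pair. The next change leads to compound 3 (`CCOC(=O)c1ccc(NC(=S)Nc2cccc(C(F)(F)F)c2)cc1`), with ethoxycarbonyl in place of hydrogen on an aromatic carbon. Within the data shown here, only one measured step bears on this change: a 3.5-fold higher number from compound 1 to compound 2 (0.55 log units; beyond the scatter) with hydrogen in place of chloro on an aromatic carbon. Read in reverse, that step pairs a group on an aromatic carbon with a lower number. It is a single example, chloro is not ethoxycarbonyl, and no ester has been measured in this series, so it is only a weak guide. A step of similar modest size towards a lower number is therefore expected, and the estimated step is a 2.6-fold lower number from compound 2 to compound 3 (0.41 log units; beyond the scatter) on this one precedent. Compound 3 is estimated at 15000 nM (expected range 5000 nM to 45000 nM).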

Compound 3, half-maximal cytotoxic concentration: 71000 nM
For compound 3 the middle estimate is 4.7-fold (0.68 log units) below the measured one; measured number above the stated range.
By their numbers in this assay, from the lowest: compound 1; then compounds 2 and 3 (each within the scatter of the next).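

In this assay, ethoxycarbonyl in place of hydrogen gives a 1.8-fold higher number from compound 2 to compound 3 (0.26 log units; within the scatter), so at this position, para to a large group, the ester is not separated from hydrogen. Ethoxycarbonyl in place of chloro gives a 6.5-fold higher number from compound 1 to compound 3 (0.81 log units; beyond the scatter), which shows that the two groups on the same aromatic carbon do not read alike. A group at this position therefore does not by itself go with a lower number: among these three compounds, only compound 1, with chloro, stands apart, and compound 2 and compound 3 stay together.

Going by these compounds, whether a carboxylic acid, an amine or a longer ester chain at this position would stay with hydrogen and ethoxycarbonyl or fall with chloro remains open. On these data alone, all three compounds also keep the trifluoromethyl group, so the effect of putting a nitrile or a methoxy group in its place on this read-out is equally open. No measurement in hand accounts for the difference between chloro and ethoxycarbonyl at this position.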